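A few compounds are considered here, and "the series" means these few. Any claim that something is new, unique, unknown or untested is made for them only; others in the source may bear on it.

Of the compounds shown here, two of a shared core have been measured so far. Compound 1 `Cc1cc(=O)n(-c2ccccc2OC(F)(F)F)nc1C(=O)Nc1ccc(Oc2ncnc3ccsc23)cc1` carries a 2-(trifluoromethoxy)phenyl group on an aromatic nitrogen, and in a functional assay on MCF7 cells (Homo sapiens) for cytotoxicity, read by MTT assay, with a stated time of 72 h (on this read-out higher numbers stand for weaker inhibition and lower numbers for stronger inhibition), compound 1 gives 23800 nM. Compound 2 `Cc1cc(=O)n(-c2ccc(Br)cc2F)nc1C(=O)Nc1ccc(Oc2ncnc3sccc23)cc1` carries a 4-bromo-2-fluorophenyl group at the same position, and in this assay compound 2 gives 15200 nM; the number for compound 1 sits within the usual scatter of that for compound 2, so the two cannot be told apart. Compound 3 `Cc1cc(=O)n(-c2ccccc2OC(F)(F)F)nc1C(=O)Nc1ccc(Oc2ncnc3sccc23)cc1` remains to be measured. It differs from compound 2 in one place: 2-(trifluoromethoxy)phenyl in place of 4-bromo-2-fluorophenyl on an aromatic nitrogen. Compound 1 shows the same entering group on a core that differs elsewhere, and its value is within the scatter of compound 2, so no step beyond the scatter is expected from compound 2 to compound 3 a 1.3-fold higher number from compound 2 to compound 3 (0.12 log units; within the scatter). For compound 3 the estimate in this assay is 20000 nM, with a range from 8000 nM to 50000 nM.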

Compound 3, half-maximal inhibitory concentration: 11000 nM
Estimate against measurement, compound 3: 1.8-fold (0.26 log units) above, within the range that was stated.
By their numbers in this assay, from the lowest: compounds 3, 2 and 1 (each within the scatter of the next, the first and the last beyond it).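

In this assay, putting 2-(trifluoromethoxy)phenyl in place of 4-bromo-2-fluorophenyl on the aromatic nitrogen gives a 1.4-fold lower number from compound 2 to compound 3 (0.14 log units; within the scatter), so this position tolerates the exchange of these two groups, which differ in their heavy atoms and hydrogen-bond acceptors, without a readable change. Going by these compounds alone, the group on the oxygen on an aromatic ring gives the first step beyond the scatter, a 2.2-fold lower number from compound 1 to compound 3 (0.34 log units; beyond the scatter), although the two groups have the same heavy atoms and the same ring types and differ only in how these are arranged. Nothing available accounts for this modest step.

The compounds shown leave open whether an amine or a carboxylic acid on the phenyl ring at the nitrogen would give a step beyond the scatter. They also leave open whether the step at the oxygen would hold with 4-bromo-2-fluorophenyl on the nitrogen.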